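This account rests on a few compounds, and the source may have more. Where it says the series, first, only, none or still open, it means among the compounds named here.

Among the measured compounds shown here, compound 3 `C=CC(=O)NC1CCC(N2C(=O)N(Cc3ccccc3)Cc3cnc(Nc4ccc(N5CCN(C)CC5)cc4OC)nc32)CC1` gives 18.8 ug/mL in a physicochemical assay for solubility, read by HPLC, in phosphate buffer, measured as thermodynamic solubility, with a stated time of 24 h, at pH 6.8 (a higher number here means a more soluble compound, a lower number a less soluble compound), the lowest of the three numbers measured so far: compound 2 `C=CC(=O)N1CCC[C@H](N2C(=O)N(Cc3ccccc3)Cc3cnc(Nc4ccc(N5CCN(C)CC5)cc4OC)nc32)C1` gives 129 ug/mL, and compound 1 `C=CC(=O)N1CC[C@H](N2C(=O)N(C3CCCC3)Cc3cnc(Nc4ccc(N5CCN(C)CC5)cc4OC)nc32)C1` gives 250 ug/mL. Compound 4 `C=CC(=O)N1CC[C@@H](N2C(=O)N(Cc3ccccc3)Cc3cnc(Nc4ccc(N5CCN(C)CC5)cc4OC)nc32)C1` carries the change (1-(vinylcarbonyl)pyrrolidin-3-yl in place of 4-((vinylcarbonyl)amino)cyclohexyl on an amide-type nitrogen in a ring). For the measured compounds named here, the one measured step that bears on this runs in the opposite sense, a 6.9-fold lower number from compound 2 to compound 3 (0.84 log units; beyond the scatter), where 4-((vinylcarbonyl)amino)cyclohexyl replaced 1-(vinylcarbonyl)piperidin-3-yl; compound 4 returns to a ring-held vinylcarbonyl, now 1-(vinylcarbonyl)pyrrolidin-3-yl, so a rise of roughly that size is expected. Going by the values given here, compound 1, which also bears a 1-(vinylcarbonyl)pyrrolidin-3-yl group, stands well above compound 3, though no single-change step links compound 1 to compound 4. The step of a 6.4-fold higher number from compound 3 to compound 4 (0.81 log units; beyond the scatter) is therefore expected. Compound 4 is estimated at 120 ug/mL, within 50 ug/mL to 300 ug/mL.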

Compound 4, solubility: 199 ug/mL
The estimate for compound 4 lay 1.7-fold (0.22 log units) below the measured number; the range from low to high includes it.
By their numbers in this assay, from the lowest: compound 3; then compounds 2, 4 and 1 (each within the scatter of the next).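

On the amide-type nitrogen in a ring, with the benzyl group held, replacing 4-((vinylcarbonyl)amino)cyclohexyl with 1-(vinylcarbonyl)pyrrolidin-3-yl in this assay gives an 11-fold higher number from compound 3 to compound 4 (1.02 log units; beyond the scatter). Replacing 1-(vinylcarbonyl)piperidin-3-yl with the same group gives a 1.5-fold higher number from compound 2 to compound 4 (0.19 log units; within the scatter), so among compounds 2, 3 and 4 only the cyclohexyl group of compound 3 stands apart. Nothing available explains the large step. Open, going by these compounds, is whether an open-chain amine on this nitrogen would keep the number near that of compound 4. Also open, on these data alone, is how a carboxylic acid at this position would read in this assay.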